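The compounds below may be only part of what the source reports. "The series", "measured", "known", "first", "only" and "open" are said of these compounds alone.

Of the compounds shown here, three sharing one core have been measured in an assay for inhibition of 3-oxo-5-alpha-steroid 4-dehydrogenase 1 (Homo sapiens), tested at 10 uM; a higher number here means more inhibition at the concentration tested (going by the name of the read-out), a lower number less inhibition. Compound 1 `O=C(O)Cc1ccc(C=C2CCN(C(=O)C(C3CCCCC3)C3CCCCC3)CC2)cc1` gives 6%. Compound 2 `O=C(O)c1ccc(C=C2CCN(C(=O)C(c3ccccc3)c3ccccc3)CC2)cc1` gives 26% in this assay, and compound 3 `O=C(O)c1cccc(C=C2CCN(C(=O)C(c3ccccc3)c3ccccc3)CC2)c1` gives 6%. Compound 1 thus stands level with compound 3 at the digits shown, and the two together form the low end of the set, while compound 2 shows the higher number. Within the data shown here, the only step measured within this set, a number 20 percentage points lower from compound 2 to compound 3 (beyond the scatter), comes from placing 3-carboxyphenyl in place of 4-carboxyphenyl; it concerns where the acid sits, not an added substituent.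

Compound 4 `O=C(O)Cc1ccc(C=C2CCN(C(=O)C(C3CCCCC3)C3CCCCC3)CC2)c(F)c1` is compound 1 with one alteration, (fluoro in place of hydrogen on an aromatic carbon). Among the measured compounds shown here, none of the measured steps introduces a fluoro group or alters this part of the molecule in a comparable way, so the data give no direct guide to the size or direction of the step. For the measured compounds named here, with compound 1 already near the floor of the read-out and no comparable precedent, the expectation is a step that stays within the scatter, a number 2 percentage points higher from compound 1 to compound 4 (within the scatter). Compound 4 is therefore estimated to give 8% in this assay, with a range from 0% to 25%.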

Compound 4, a percentage reported as inhibition, at one concentration (the size of the read-out at that concentration, not a potency): 4%
Beside the measured number, compound 4's estimate is 4 percentage points above it; the measured number falls inside the stated range.
By their numbers in this assay, from the lowest: compounds 4, 1 and 3 (each within the scatter of the next); then compound 2.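

In this assay, fluoro in place of hydrogen on an aromatic carbon, ortho to a large group and meta to a carboxymethyl group, amounts to a number 2 percentage points lower from compound 1 to compound 4 (within the scatter). Among these compounds, this is the first reading at this aromatic carbon, and it shows that a single fluoro here brings no difference that can be told apart from the usual variation between repeated measurements, so it does not lift this series out of the low end of the set. No measurement is available that could explain this result in terms of how the fluoro acts on the molecule.

As far as these compounds go, it remains open whether chloro, methoxy or an amine on the same aromatic carbon would give a step beyond the scatter, since a single small substituent cannot speak for other groups at this place. From the compounds shown here alone, it is also open whether fluoro would behave the same way in a compound starting from a clearly higher number, such as compound 2 at 26%, where a loss of inhibition would have more room to show.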